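Replacing a cyanoguanidine with a smaller thiourea group

The source may hold more compounds than are shown below. What is called first, only, known or untested is meant among the compounds shown, and "the series" means these compounds.

Measured compounds:
compound 1 `CCC/N=C(/NC#N)NCCCCCn1nc(-c2ccccc2)ccc1=O` — > 100 mg/kg
compound 2 `CCC/N=C(/NC#N)NCCCn1nc(-c2ccccc2)ccc1=O` — 100 mg/kg

For the measured compounds named here, in a functional assay on the whole organism (stomach) with Rattus norvegicus as the target (on this read-out lower numbers stand for an effect already at smaller amounts and higher numbers for an effect only at larger amounts of compound), compound 2 gives 100 mg/kg, the only definite number among the two values shown. Compound 1 reaches only the limit of > 100 mg/kg in this assay, at which 1 of the 2 values shown sits, in this assay, a limit and not a number. Compound 3 `C/N=C(\S)NCCCn1nc(-c2ccccc2)ccc1=O` differs from compound 2 by a group of 4 heavy atoms (2 carbon, 1 nitrogen, 1 sulfur; no ring) in place of a group of 8 heavy atoms (5 carbon, 3 nitrogen; no ring), on an amine nitrogen. Going by the values given here, no measured step of this kind exists here, so compound 3 is expected to stay close to compound 2, and the expected step of no change at the digits printed from compound 2 to compound 3 (within the scatter) is none beyond the scatter. The estimated value for compound 3 is 100 mg/kg, with a range from 30 mg/kg to 300 mg/kg.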

Compound 3, dose for half-maximal effect: > 100 mg/kg
Compound 3 gave a limit, no number (the forecaster's own chance of this, stated with the estimate: 40%); the middle value sits exactly at the limit.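

In this assay, placing the group of 4 heavy atoms on the amine nitrogen instead of the group of 8 heavy atoms gives a number no lower from compound 2 to compound 3 (the limit leaves the size open). As far as these compounds go, the result for compound 3 is a limit, not a number, so this change shows no gain at this position, while the size of any loss stays unknown. Definite numbers are scarce in this set: the limit of > 100 mg/kg in this assay, at which 2 of the 3 values shown sit.

The compounds shown leave open how far compound 3 actually lies from compound 2. They also leave open whether a urea or a carboxylic acid in this place would give a lower number.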